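The source may report more compounds than this note shows. Statements on the series, on what has been measured and on what is new or still open speak of the compounds shown alone.

Compound 1 `O=C(/C=C/c1ccccc1F)c1ccccc1` and compound 2 `O=C(/C=C/c1ccccc1F)c1ccccc1O` differ by hydroxy in place of hydrogen on an aromatic carbon. In a functional assay on RAW264.7 cells (Mus musculus) for inhibition, read by fluorescence, with stated times of 1 h, 24 h and 30 min (a higher number here means a weaker inhibitor, a lower number a stronger inhibitor), compound 1 gives > 10000 nM, which is a limit of the assay. In this assay compound 2 gives > 10000 nM, also a limit. The step that the two limits leave unreadable from compound 1 to compound 2 cannot be read because of the limit of > 10000 nM in this assay, at which 3 of the 3 values shown sit. Compound 3 `O=C(/C=C/c1cccc(F)c1)c1ccccc1` has the same atoms as compound 1 joined differently; how the two cores differ is not broken down here. In this assay compound 3 gives > 10000 nM, again a limit. Compound 4 `O=C(/C=C/c1cccc(F)c1)c1ccc(O)cc1` differs from compound 3 by hydroxy in place of hydrogen on an aromatic carbon; this is the same kind of change as from compound 1 to compound 2, but the place differs: ortho to a large group there, para to a large group here. With the earlier step unreadable and (the limit of > 10000 nM in this assay, at which 3 of the 3 values shown sit), the expected step is a step that the limit leaves unreadable from compound 3 to compound 4. Compound 4 is therefore estimated at 15000 nM in this assay, most probably reported only as a limit.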

Compound 4, half-maximal inhibitory concentration: 9150 nM
For compound 4 the middle estimate is 1.6-fold (0.21 log units) above the measured one; the range from low to high includes it.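

In this assay, compound 3 gives > 10000 nM, which is a limit, and hydroxy in place of hydrogen on an aromatic carbon, para to a large group, gives an at least 1.0-fold lower number from compound 3 to compound 4 (0.03 log units; that floor lies within the scatter). Only a floor of this step can be read, and it does not show that the hydroxy change lowers the number on the core of compound 3. The same kind of change on the core of compound 1 cannot be read either, so carrying it from one core to the other is not shown: the limit of > 10000 nM in this assay, at which 3 of the 4 values shown sit.

As far as these compounds go, it remains open whether an amine, a carboxylic acid or a methoxy group at that place would give a readable value. From the compounds shown here alone, the effect of hydroxy at the same place on the core of compound 1 also remains open.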